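Cytotoxicity notes on a pyrrole-hydrazine series

The source may report more compounds than this note shows. Statements on the series, on what has been measured and on what is new or still open speak of the compounds shown alone.

Measured compounds:
- compound 1, `Cc1c(CN2CCCC2)cc(-c2ccc(F)cc2)n1Nc1ccnc2cc(Cl)ccc12`, "not determined" (no result reported) in an ADME assay on HDF cells (Homo sapiens) for cytotoxicity, read by MTT assay, with a stated time of 72 h; on this read-out lower numbers stand for higher toxicity in this test and higher numbers for lower toxicity in this test
- compound 2, `CCN(CC)Cc1cc(-c2ccc(C)cc2)n(Nc2ccnc3cc(Cl)ccc23)c1C`, 10300 nM in this assay

Within the data shown here, compound 2 is the only member of the series for which this assay has returned a number; compound 1 carries no result in this assay, so its standing against compound 2 cannot be read. Compound 2 therefore stands alone as the reference point for the half-maximal cytotoxic concentration in the series.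

Compound 3, `Cc1ccc(-c2cc(CN3CCCC3)c(C)n2Nc2ccnc3cc(Cl)ccc23)cc1`, shares the core of compound 2 and differs from it in one place: pyrrolidin-1-yl in place of diethylamino on a saturated chain carbon bound to an aromatic carbon. The group that leaves and the group that enters are of the same size, and both are single amines; the change only closes the two ethyl arms into a five-membered ring.

Among the measured compounds shown here, no measured step in this assay connects two compounds that differ in this way, so there is no direct precedent to lean on. On the shape of the change alone, no step beyond the scatter in this assay is expected in either direction. The half-maximal cytotoxic concentration of compound 3 is estimated at 10000 nM, with a range of 4000 nM to 25000 nM, which corresponds to an expected step of a 1.0-fold lower number from compound 2 to compound 3 (0.01 log units; within the scatter).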

Compound 3, half-maximal cytotoxic concentration: 13200 nM
Estimate against measurement, compound 3: 1.3-fold (0.12 log units) below, and the stated range covers the measured number.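

In this assay the series now has its first measured step at this position, a 1.3-fold higher number from compound 2 to compound 3 (0.11 log units; within the scatter) and so closing the two ethyl arms of diethylamino into the five-membered ring of pyrrolidin-1-yl, with the same heavy-atom count on both sides, gives two compounds that the read-out does not separate. For the saturated chain carbon bound to an aromatic carbon, this shows that one exchange of a ring amine for an open-chain amine can pass without a step beyond the usual scatter, though a single pair sets no trend for the series. No measurement on hand links this result to any property of either amine.

Compound 1 carries no number in this assay and its step to compound 3, fluoro against methyl, cannot be read. From the compounds shown here alone, whether morpholin-4-yl, a primary amine or a longer chain carrying the amine on the same carbon would also stay within the scatter of compound 2 remains open.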